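Extending the alkyne chain by one carbon in a cytotoxicity series

The source may hold more compounds than are shown below. What is called first, only, known or untested is meant among the compounds shown, and "the series" means these compounds.

The series is read in a functional assay on HEL cells (Homo sapiens), read by microscopy; a lower number here means that less compound is tolerated, a higher number that more compound is tolerated. Compound 1 `CCCCCCCCCCc1cc2cn(COCCO)c(O)nc-2n1` carries a saturated decyl chain on the core and gives 80000 nM in this assay. Compound 2 `CCCCc1cc2cn(COCCO)c(=O)nc2o1` carries a butyl chain, and in this assay compound 2 reaches only a limit of the assay, > 400000 nM, and no number. Compound 3 `CCCCCCC#Cc1cc2cn(COCCO)c(=O)nc2o1` carries a heptynyl chain, and in this assay compound 3 likewise reaches only a limit of the assay, > 200000 nM. Compound 3 therefore stands at the limit of > 200000 nM in this assay, at which 1 of the 3 values shown sits, while the limit of > 400000 nM in this assay, at which 1 of the 3 values shown sits, is the other limit in the set, and compound 1 alone has a measured number, which lies below both limits.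

Compound 4 `CCCCCCCC#Cc1cc2cn(COCCO)c(=O)nc2o1` differs from compound 3 by methyl in place of hydrogen on a saturated chain carbon, six bonds along the chain from a triple-bonded carbon. Going by the values given here, no measured step of this kind exists in the set, so there is nothing to say about a direction from the data. Compound 4 is estimated to stay close to compound 3, with an expected step of a number no higher from compound 3 to compound 4 (the limit leaves the size open) that lies within the scatter. Compound 4 is thus estimated at 200000 nM, with a range from 100000 nM to 400000 nM, and it is expected that this assay may again report only a limit for compound 4.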

Compound 4, minimum cytotoxic concentration: 200000 nM
Beside the measured number, compound 4's estimate shows no gap at the digits printed, within the range that was stated.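

In this assay, compound 4 gives a measured number, 200000 nM, which makes it the first compound shown with a triple bond in its chain to give a value that is not a limit. Placing methyl in place of hydrogen on a saturated chain carbon, six bonds along the chain from a triple-bonded carbon, gives the first step at this position, a number no higher from compound 3 to compound 4 (the limit leaves the size open), and its size cannot be read. The reading stays open on one side, as the value of compound 3 is only a limit of the assay: the limit of > 200000 nM in this assay, at which 1 of the 4 values shown sits.

With a single step of unreadable size, the compounds shown leave open whether adding methyl at this position changes the minimum cytotoxic concentration at all, and whether a longer chain at the same place would give a lower number in this assay. They also leave open what a terminal amine or a carboxylic acid on the same chain would give, as every chain shown ends in a plain alkyl group.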